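Naphthalenyl Replaces Formylphenyl on a Shared Imidazopyrazine-Type Core

This account rests on a few compounds, and the source may have more. Where it says the series, first, only, none or still open, it means among the compounds named here.

Compound 1 `COc1ccc(-c2cn3ccnc3c(-c3ccc4ncn(C5CCCCC5)c4c3)n2)cc1`: 82.8%
Compound 2 `O=Cc1ccc(-c2cn3ccnc3c(-c3ccc4ncn(C5CCCCC5)c4c3)n2)cc1`: 58.7%

In a functional assay on MOLT-4 cells (Homo sapiens) for inhibition, read by sulforhodamine B assay, with a stated time of 48 h, tested at 10 uM (a lower number here means less inhibition, a higher number more inhibition at the concentration tested (going by the name of the read-out)), compound 2 stands lowest of the two measured compounds, with compound 1 sitting higher by a number 24.1 percentage points lower from compound 1 to compound 2 (beyond the scatter). Compound 3 `c1ccc2c(-c3cn4ccnc4c(-c4ccc5ncn(C6CCCCC6)c5c4)n3)cccc2c1` differs from compound 2 by naphthalen-1-yl in place of 4-formylphenyl on an aromatic carbon. Within the data shown here, the only measured step, a number 24.1 percentage points lower from compound 1 to compound 2 (beyond the scatter), swaps one para substituent on that phenyl and does not cover a fused bicyclic replacement, so it bears on the new step only loosely. Compound 3 is therefore expected to score 68% (range 40% to 92%), a step of a number 9.3 percentage points higher from compound 2 to compound 3 (within the scatter) that is uncertain in direction and may stay within the scatter.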

Compound 3, a percentage reported as inhibition, at one concentration (the size of the read-out at that concentration, not a potency): 44.7%
Beside the measured number, compound 3's estimate is 23.3 percentage points above it; measured number inside the range.
By their numbers in this assay, from the lowest: compound 3; then compound 2; then compound 1.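

Naphthalen-1-yl at this aromatic carbon in this assay gives a number 14 percentage points lower from compound 2 to compound 3 (beyond the scatter) and a number 38.1 percentage points lower from compound 1 to compound 3 (beyond the scatter), so compound 3 is the lowest of the three. Among these compounds, the earlier compounds showed only that the group on the phenyl matters; this result shows that replacing the whole 4-substituted phenyl with a fused carbon bicycle costs more inhibition than either phenyl compound shows. Nothing available explains this order.

From the compounds shown here alone, it remains open whether an unsubstituted phenyl would fall with compound 3 or with compound 2. Going by these compounds, how an amine or a carboxylic acid on that phenyl would score also remains open.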